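Ester in place of aziridine amide: solubility estimate

This account rests on a few compounds, and the source may have more. Where it says the series, first, only, none or still open, it means among the compounds named here.

Compound 1 `Cc1cc(/C=C/C#N)cc(C)c1Oc1cc(Nc2ccc(C#N)cc2)c(N)cc1C(=O)NCCCO`: 19.9 ug/mL
Compound 2 `Cc1cc(/C=C/C#N)cc(C)c1Oc1cc(Nc2ccc(C#N)cc2)c(N)cc1C(=O)N1CC1`: 94.2 ug/mL

For the measured compounds named here, in a physicochemical assay for solubility, read by HPLC, with a stated time of 4 h, at pH 2 (a higher number here means a more soluble compound, a lower number a less soluble compound), compound 2 gives 94.2 ug/mL, the higher of the two numbers; the one step measured, a 4.7-fold higher number from compound 1 to compound 2 (0.68 log units; beyond the scatter), is the only comparison in hand. Compound 3 `COC(=O)c1cc(N)c(Nc2ccc(C#N)cc2)cc1Oc1c(C)cc(/C=C/C#N)cc1C` differs from compound 2 by methoxy in place of aziridin-1-yl on a carbonyl carbon. Going by the values given here, no measured step bears on this change, so the step is read as uncertain in direction and modest in size. Compound 3 is expected to give 50 ug/mL, between 15 ug/mL and 160 ug/mL, in this assay, a step of a 1.9-fold lower number from compound 2 to compound 3 (0.28 log units; within the scatter).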

Compound 3, solubility: 21.8 ug/mL
Compound 3: middle estimate off by 2.3-fold (0.36 log units), on the high side; the measured number falls inside the stated range.
By their numbers in this assay, from the lowest: compounds 1 and 3 (each within the scatter of the next); then compound 2.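

On the carbonyl carbon, methoxy in place of aziridin-1-yl gives a 4.3-fold lower number from compound 2 to compound 3 (0.64 log units; beyond the scatter) in this assay, so the higher number of compound 2 does not carry over to the methoxycarbonyl group. Methoxy in place of (3-hydroxypropyl)amino gives a 1.1-fold higher number from compound 1 to compound 3 (0.04 log units; within the scatter), which leaves aziridin-1-yl as the only one of the three groups that stands apart. Nothing measured here accounts for this. Still open, from the compounds shown here alone, is whether a larger cyclic amine on this carbonyl carbon, such as azetidin-1-yl or pyrrolidin-1-yl, would keep the number of compound 2. Going by these compounds, how a carboxylic acid in this place would read in this assay is also open.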